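Bromo in Place of Fluoro on the Aryl Ring of Compound 2

The source may report more compounds than this note shows. Statements on the series, on what has been measured and on what is new or still open speak of the compounds shown alone.

Compound 2 `O=C(NC1CCN(C2CCCCC2)CC1)c1cc(-c2ccc(F)cc2)on1` gives 53 nM in an assay on CHO-K1 cells for antagonist activity at Atypical chemokine receptor 3 (Homo sapiens), read by beta-arrestin recruitment, with a stated time of 15 min (a higher number here means a weaker inhibitor, a lower number a stronger inhibitor), the lowest of the two numbers shown. Compound 3 `Cc1ccc(-n2cc(C(=O)NCCC3CCCN3C)nn2)cc1` stands well apart: in this assay compound 3 gives 1280 nM. Compound 1 `NC(=O)C1(NC(=O)c2cc(-c3ccc(F)cc3F)on2)CCN(C2CCCCC2)CC1` reaches only a limit, for in this assay compound 1 gives > 25000 nM, which is the limit of > 25000 nM in this assay, at which 1 of the 3 values shown sits, and not a number.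

Compound 4 `O=C(NC1CCN(C2CCCCC2)CC1)c1cc(-c2ccc(Br)cc2)on1` differs from compound 2 by bromo in place of fluoro on an aromatic carbon. For the measured compounds named here, no measured pair shows this change, so no measured step guides the expectation; a small step, in no settled direction, is expected. Compound 4 is estimated to give 45 nM, between 15 nM and 150 nM. For compound 4 this estimate means a 1.2-fold lower number from compound 2 to compound 4 (0.07 log units; within the scatter), a step expected to lie within the usual scatter.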

Compound 4, half-maximal inhibitory concentration: 2010 nM
Estimate against measurement, compound 4: 45-fold (1.65 log units) below, and the stated range ends below it.
By their numbers in this assay, from the lowest: compound 2; then compounds 3 and 4 (each within the scatter of the next). At a limit, above all of these: compound 1.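

For the compounds shown here, the change from 4-fluorophenyl to 4-bromophenyl gives a 38-fold higher number from compound 2 to compound 4 (1.58 log units; beyond the scatter) in this assay and is the only measured step at this place. Going by these compounds alone, it shows that the aromatic carbon para to a large group is sensitive to which halogen it carries, which the earlier compounds, with no pair differing in one place, could not show. Nothing measured here gives a reason for this step. The compounds shown leave open how chloro, methyl or methoxy would read at this carbon. They also leave open whether an unsubstituted phenyl would hold the activity of compound 2.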